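Compound 2 to compound 4: a changed aryl carbonyl group

The source may hold more compounds than are shown below. What is called first, only, known or untested is meant among the compounds shown, and "the series" means these compounds.

In an in vitro ADME assay on microsomes from liver (Homo sapiens) for metabolic stability (on this read-out lower numbers stand for slow clearance and higher numbers for fast clearance), compound 2 (`COc1ccc(O)c(C(=O)N2CCC(=CC(=O)N[C@@H]3CCN(Cc4ccc5cc(F)ccc5c4)C3)CC2)c1`) gives 119 mL/min/kg and compound 1 (`O=C(C=C1CCN(C(=O)c2ccc(F)cc2)CC1)N[C@@H]1CCN(Cc2ccc3cc(F)ccc3c2)C1`) gives 237 mL/min/kg with a 2.0-fold lower number from compound 1 to compound 2 (0.30 log units; within the scatter) between them. Within the data shown here, compound 3 (`O=C(C=C1CCN(C(=O)c2cccc(F)c2)CC1)N[C@@H]1CCN(Cc2ccc3cc(F)ccc3c2)C1`) gives 459 mL/min/kg and a 3.9-fold higher number from compound 2 to compound 3 (0.59 log units; beyond the scatter) is the only step that clears the scatter. Compound 2 therefore sits at the low end of the three numbers, level with compound 1 within the scatter.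

Compound 4 (`O=C(C=C1CCN(C(=O)c2ccc(Cl)cc2O)CC1)N[C@@H]1CCN(Cc2ccc3cc(F)ccc3c2)C1`) brings 4-chloro-2-hydroxyphenyl in place of 2-hydroxy-5-methoxyphenyl on a carbonyl carbon with 4-chloro-2-hydroxyphenyl in place of 2-hydroxy-5-methoxyphenyl on a carbonyl carbon. Among the measured compounds shown here, no measured compound carries this group. Steps at this place reach a 3.9-fold higher number from compound 2 to compound 3 (0.59 log units; beyond the scatter) and both steps out of compound 2 go upward, so a small rise is expected, probably within the scatter. The expected move is a 1.6-fold higher number from compound 2 to compound 4 (0.20 log units; within the scatter) on this estimate. Compound 4 is estimated at 190 mL/min/kg with an expected range of 95 mL/min/kg to 380 mL/min/kg overall.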

Compound 4, clearance: 87 mL/min/kg
Compound 4: the middle estimate sits 2.2-fold (0.34 log units) above what was measured, and the stated range ends above it.
By their numbers in this assay, from the lowest: compounds 4, 2, 1 and 3 (each within the scatter of the next, the first and the last beyond it).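

In this assay, 4-chloro-2-hydroxyphenyl and 2-hydroxy-5-methoxyphenyl on the carbonyl carbon read level (a 1.4-fold lower number from compound 2 to compound 4 (0.14 log units; within the scatter)), so this change of substituents on a hydroxyphenyl group leaves the number within the scatter. Compound 4 also stands clear of both fluorophenyl compounds (a 5.3-fold lower number from compound 3 to compound 4 (0.72 log units; beyond the scatter); a 2.7-fold lower number from compound 1 to compound 4 (0.44 log units; beyond the scatter)), whereas compound 2 stood clear only of compound 3. The compounds shown do not separate the contribution of the hydroxy group from that of the chlorine, which a plain 2-hydroxyphenyl or 4-chlorophenyl group would do. No measured data offer an explanation for these differences.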